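Lengthening the Alkyl Chain of a Threonine Amide

The source may report more compounds than this note shows. Statements on the series, on what has been measured and on what is new or still open speak of the compounds shown alone.

Of the compounds shown here, three have been measured in a functional assay on A-431 cells (Homo sapiens) for cytotoxicity, read by MTT assay, with a stated time of 48 h; a lower number here means a stronger inhibitor, a higher number a weaker inhibitor. Compound 1 `CCCCCCCCCCCCNC(=O)[C@@H](NC(=O)c1ccccc1)[C@@H](C)O` gives 41200 nM. Compound 2 `CCCCCCCCCCCCNC(=O)[C@@H](NC(=O)c1cc2ccccc2n1C)[C@@H](C)O` gives 169000 nM. Compound 3 `C/C=C/C=C/C(=O)N[C@H](C(=O)NCCCCCCCCCCCC)[C@@H](C)O` gives 171000 nM.

Compound 3 stands highest of the three numbers. One gap is within the scatter: a 1.0-fold higher number from compound 2 to compound 3 (0.01 log units; within the scatter). The other lies beyond it: a 4.2-fold higher number from compound 1 to compound 3 (0.62 log units; beyond the scatter). Compound 4 `C/C=C/C=C/C(=O)N[C@H](C(=O)NCCCCCCCCCCCCCC)[C@@H](C)O` differs from compound 3 by ethyl in place of hydrogen on a saturated chain carbon, ten or more bonds along the chain from an amide-type nitrogen. Among the compounds with values here, none of the measured steps touches this chain; each of them, a 4.1-fold higher number from compound 1 to compound 2 (0.61 log units; beyond the scatter) included, changed the group on the carbonyl carbon instead. There is therefore nothing to point to a step beyond the scatter in this assay in either direction. Compound 4 is expected to give about 170000 nM, within a range of 60000 nM to 500000 nM, which means an expected step of a 1.0-fold lower number from compound 3 to compound 4 (0.00 log units; within the scatter).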

Compound 4, half-maximal inhibitory concentration: > 200000 nM
Compound 4: only a limit was reported (the forecaster's own chance of this, stated with the estimate: 20%); at least 1.1-fold (0.07 log units) between middle value and limit.
By their numbers in this assay, from the lowest: compound 1; then compounds 2 and 3 (each within the scatter of the next). At a limit, above all of these: compound 4.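

Within the data shown here, this is the first change made to the alkyl chain itself, not to the group on the carbonyl carbon. In this assay compound 4 gives > 200000 nM, which is a limit of the assay and not a number. The step, an at least 1.1-fold higher number from compound 3 to compound 4 (0.06 log units; that floor lies within the scatter), shows no gain in strength from ethyl in place of hydrogen at this place on the saturated chain, but its floor cannot say whether the change had any effect.

As far as these compounds go, how far the true value of compound 4 lies past its limit stays open. So does whether a shorter chain, or an amine or a carboxylic acid on this chain, would shift the number in this assay.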